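Cyclohexyl to Chloropyridyl on the Piperazine Nitrogen

This account rests on a few compounds, and the source may have more. Where it says the series, first, only, none or still open, it means among the compounds named here.

Compound 1 `CC1CCC(Nc2nc(C(F)(F)F)ccc2CNC(=O)C(C)c2ccc(NS(C)(=O)=O)c(F)c2)CC1`: 27.2 nM
Compound 2 `Cc1ccc(Nc2nc(C(F)(F)F)ccc2CNC(=O)C(C)c2ccc(NS(C)(=O)=O)c(F)c2)cc1C`: 39.3 nM
Compound 3 `CC(C(=O)NCc1ccc(C(F)(F)F)nc1N1CCN(C2CCCCC2)CC1)c1ccc(NS(C)(=O)=O)c(F)c1`: 21.6 nM

In a functional assay on CHO-K1 cells for antagonist activity at transient receptor potential cation channel subfamily V member 1 (Homo sapiens), read by FLIPR (on this read-out lower numbers stand for stronger inhibition and higher numbers for weaker inhibition), compound 3 gives the lowest of the three numbers, yet its steps to the others, a 1.3-fold lower number from compound 1 to compound 3 (0.10 log units; within the scatter) and a 1.8-fold lower number from compound 2 to compound 3 (0.26 log units; within the scatter), both lie within the scatter, so no order among them can be claimed. Compound 4 `CC(C(=O)NCc1ccc(C(F)(F)F)nc1N1CCN(c2ncccc2Cl)CC1)c1ccc(NS(C)(=O)=O)c(F)c1` differs from compound 3 by 3-chloropyridin-2-yl in place of cyclohexyl on an amine nitrogen in a ring. Among the compounds with values here, the nearest precedent among the measured pairs is a 1.4-fold higher number from compound 1 to compound 2 (0.16 log units; within the scatter), where a cyclohexyl ring on a nitrogen gave way to an aromatic ring without moving beyond the scatter. On that basis the step of a 1.4-fold higher number from compound 3 to compound 4 (0.14 log units; within the scatter) is expected to stay within the scatter as well. Compound 4 is therefore estimated at 30 nM, with a range from 10 nM to 90 nM.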

Compound 4, inhibition constant: 2.1 nM
Compound 4: middle estimate off by 14-fold (1.15 log units), on the high side; the measured number lies below the stated range.
By their numbers in this assay, from the lowest: compound 4; then compounds 3, 1 and 2 (each within the scatter of the next).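

In this assay the change from cyclohexyl to 3-chloropyridin-2-yl on the amine nitrogen in a ring gives a 10-fold lower number from compound 3 to compound 4 (1.01 log units; beyond the scatter) and is the only step shown that lies beyond the scatter. Within the data shown here, this position therefore responds to the group it carries, which the earlier steps, all within the scatter, did not reveal. No available evidence accounts for the size of this step. The compounds shown leave open whether the aromatic ring, its ring nitrogen or its chlorine carries the change. A phenyl ring, a plain pyridin-2-yl or a fluorine in place of the chlorine would separate these.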